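This account rests on a few compounds, and the source may have more. Where it says the series, first, only, none or still open, it means among the compounds named here.

Measured in a functional assay on Caco-2 cells (Homo sapiens) for antiproliferative activity, read by MTT assay, with a stated time of 48 h; on this read-out higher numbers stand for weaker inhibition and lower numbers for stronger inhibition:
- Compound 1 `C=CCN(C)C(=O)c1ccc(C(CC)(CC)c2ccc(OCCC(O)(CC)CC)c(C)c2)n1CC`: > 50000 nM, a limit
- Compound 2 `CCC(C)C(NC(=O)c1ccc(C(CC)(CC)c2ccc(OCCC(O)(CC)CC)c(C)c2)n1CC)C(=O)OC`: > 50000 nM, a limit
- Compound 3 `CCC(C)C(NC(=O)c1ccc(C(CC)(CC)c2ccc(OCCC(O)(CC)CC)c(C)c2)n1CC)C(=O)O`: 20000 nM

Among the compounds with values here, compound 3 gives the only number here and is the most potent of the three. Compound 4 `CCn1c(C(=O)NC(CO)CCO)ccc1C(CC)(CC)c1ccc(OCCC(O)(CC)CC)c(C)c1` carries 3-hydroxy-1-(hydroxymethyl)propyl in place of 1-carboxy-2-methylbutyl on an amide-type nitrogen. Within the data shown here, two measured steps bear on this: an at least 2.5-fold lower number from compound 1 to compound 3 (0.39 log units; beyond the scatter) and an at least 2.5-fold lower number from compound 2 to compound 3 (0.39 log units; beyond the scatter). Among the measured compounds shown here, both are at least modest, and both end at the only compound carrying the carboxy group, which compound 4 gives up. A small shift toward weaker inhibition is therefore expected, possibly within the scatter, and a limit reading in this assay would fit as well. The expected change is a 1.8-fold higher number from compound 3 to compound 4 (0.24 log units; within the scatter). For compound 4 the estimate is 35000 nM, with an expected range of 12000 nM to 90000 nM.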

Compound 4, half-maximal inhibitory concentration: 40200 nM
Beside the measured number, compound 4's estimate is 1.1-fold (0.06 log units) below it; the range from low to high includes it.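

In this assay, a readable number on the amide-type nitrogen does not depend on 1-carboxy-2-methylbutyl: 3-hydroxy-1-(hydroxymethyl)propyl gives a 2.0-fold higher number from compound 3 to compound 4 (0.30 log units; within the scatter). The comparisons with the other two compounds are an at least 1.2-fold lower number from compound 2 to compound 4 (0.09 log units; that floor lies within the scatter) and an at least 1.2-fold lower number from compound 1 to compound 4 (0.09 log units; that floor lies within the scatter). Both are floors set by a limit of the assay, not by a number: the limit of > 50000 nM in this assay, at which 2 of the 4 values shown sit.

As far as these compounds go, whether an amine or a longer chain on the amide-type nitrogen would move the number beyond the scatter stays open. So does the effect of a single hydroxyethyl group there.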